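The compounds below may be only part of what the source reports. "The series", "measured", "known", "first", "only" and "open" are said of these compounds alone.

Working notes, series around compound 2.

Compound 1 `Cc1ccc(SCc2ccc(/C=C/C(=O)Nc3ccccc3N)cc2)cc1` carries 4-methylphenyl on the sulfur; in a functional assay on SMMC-7721 cells (Homo sapiens) for inhibition, read by CCK-8 assay, with a stated time of 72 h, tested at 2 uM (a higher number here means more inhibition of growth at the concentration tested, a lower number less inhibition of growth), compound 1 gives 22%. Compound 2 `COc1ccc(SCc2ccc(/C=C/C(=O)Nc3ccccc3N)cc2)cc1OC` carries 3,4-dimethoxyphenyl in that place; in this assay compound 2 gives 14.3%, the lowest number of the three measured, though compound 1 lies within the scatter of it, and compound 3 is the furthest away. Compound 3 `Nc1ccccc1NC(=O)c1ccc(CSc2nccc(C(F)(F)F)n2)cc1` is built on a different core; in this assay compound 3 gives 66.1%, a gap to compound 2 that is beyond the scatter. Among the compounds with values here, the only step on the shared core, a number 7.7 percentage points lower from compound 1 to compound 2 (within the scatter), stays within the scatter.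

Compound 4 `Nc1ccccc1NC(=O)/C=C/c1ccc(CSc2ccc(F)cc2)cc1` is not yet measured. Against compound 2 the change is 4-fluorophenyl in place of 3,4-dimethoxyphenyl on a sulfur. Within the data shown here, the one step that bears on it is the earlier exchange of an aryl group on the sulfur, a number 7.7 percentage points lower from compound 1 to compound 2 (within the scatter), which did not move the number beyond the scatter. Compound 3 gives a high number, but its core differs from the shared core, so it says nothing about aryl exchange here. No step beyond the scatter is therefore expected in this assay, in either direction. Compound 4 is expected to give 20%, within 8% to 36%. The expected step, a number 5.7 percentage points higher from compound 2 to compound 4 (within the scatter), is estimated to remain within the scatter.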

Compound 4, percent growth inhibition at one concentration: 18.3%
Compound 4: the middle estimate sits 1.7 percentage points above what was measured, within the range that was stated.
By their numbers in this assay, from the lowest: compounds 2, 4 and 1 (each within the scatter of the next); then compound 3.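

In this assay the step to 4-fluorophenyl in place of 3,4-dimethoxyphenyl on the sulfur reads as a number 4 percentage points higher from compound 2 to compound 4 (within the scatter) and the step to fluoro in place of methyl on an aromatic carbon reads as a number 3.7 percentage points lower from compound 1 to compound 4 (within the scatter) on the same shared core. Within the data shown here, the position on the sulfur has now been read with three aryl groups, and no pair among compounds 1, 2 and 4 is separated beyond the scatter, even though the group leaving in the step to compound 4 has 2 hydrogen-bond acceptors and the entering group has 0. Nothing at hand speaks to the reason for this result.

As far as these compounds go, whether a carboxylic acid or an amine on the aryl ring, or a longer alkyl chain in place of the aryl group on the sulfur, would move the number beyond the scatter remains open. In this assay compound 3 gives 66.1% on a different core, and no compound shown links that core to the shared core one change at a time, so that number remains unassigned to any single structural feature.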